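A few compounds are considered here, and "the series" means these few. Any claim that something is new, unique, unknown or untested is made for them only; others in the source may bear on it.

Of the compounds shown here, three of a shared core have been measured in a functional assay on Hs-578T cells (Homo sapiens) for inhibition, read by sulforhodamine B assay, with a stated time of 48 h; a lower number here means a stronger inhibitor of growth, a higher number a weaker inhibitor of growth. Compound 1 `COc1cc(C)cc(-c2nn(CC#N)cc2-c2ccc(-c3cccc(C(C)=O)c3)nc2)c1` gives 3870 nM in this assay. Compound 2 `Cc1cc(O)cc(-c2nn(CC#N)cc2-c2ccnc(-c3ccc(Oc4ccccc4)cc3)c2)c1`, which carries the hydroxy group on one side and a different aryl group on the other, gives 6080 nM. Compound 3 `COc1cc(C)cc(-c2nn(CC#N)cc2-c2ccnc(-c3ccc(N(C)C)cc3)c2)c1` gives 695 nM, the lowest of the three numbers; its gaps to compound 1 and to compound 2 both lie beyond the usual scatter, so it is the strongest inhibitor of growth among them. Among the compounds with values here, compound 2 and compound 3 differ in two places at once, so their two values show only that the pair with the phenoxy group and the hydroxy group together sits higher.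

Compound 4 `Cc1cc(O)cc(-c2nn(CC#N)cc2-c2ccnc(-c3ccc(N(C)C)cc3)c2)c1` has not yet been measured. It differs from compound 3 by hydrogen in place of methyl on an oxygen on an aromatic ring, the same change read one bond further out as methoxy to hydroxy. Within the data shown here, no measured pair isolates this single change, so the step of a 1.7-fold higher number from compound 3 to compound 4 (0.24 log units; within the scatter) is an expectation only: a small weakening is estimated, close to the edge of the scatter, with the chance that no real change appears. On that basis compound 4 is expected to give about 1200 nM in this assay, in a range from 400 nM to 4000 nM.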

Compound 4, concentration for total growth inhibition: 7000 nM
Compound 4: middle estimate off by 5.8-fold (0.77 log units), on the low side, outside the stated range (above it).
By their numbers in this assay, from the lowest: compound 3; then compounds 1, 2 and 4 (each within the scatter of the next).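

In this assay, within the data shown here, hydrogen in place of methyl on an oxygen on an aromatic ring gives a 10-fold higher number from compound 3 to compound 4 (1.00 log units; beyond the scatter), the first single change with a measured effect, and it shows that with dimethylamino held fixed, the methoxy form is the stronger inhibitor of growth and the hydroxy form the weaker. With the hydroxy group held fixed, dimethylamino in place of phenoxy on an aromatic carbon gives a 1.2-fold higher number from compound 2 to compound 4 (0.06 log units; within the scatter), so this change shows no real difference in that pair, and dimethylamino alone does not bring the low number seen for compound 3. Nothing among the data shown accounts for the size of the methoxy to hydroxy step.

The compounds shown leave open whether that step keeps its size with phenoxy in place of dimethylamino, and whether the aryl change matters once methoxy stands on the ring. They also leave open how a longer chain on that oxygen, such as ethoxy, or an amine in place of the methoxy group, would read in this assay.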